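The source may hold more compounds than are shown below. What is called first, only, known or untested is meant among the compounds shown, and "the series" means these compounds.

In an ADME assay on KB cells (Homo sapiens) for cytotoxicity (on this read-out higher numbers stand for an effect only at larger amounts of compound and lower numbers for an effect already at smaller amounts), compound 1 (`CCOC(=O)N1[C@@H]2C=C[C@@](OC)(C(=O)c3c2cc(OC)c(OC)c3OCC)N1C(=O)OCC`) gives > 300 ug/mL, a limit and not a number. Compound 2 (`COC(=O)N1[C@@H]2C=C[C@@](OC)(C(=O)c3c2cc(OC)c(OC)c3OCc2ccc(OC)cc2)N1C(=O)OC`) gives > 300 ug/mL, also a limit. Among the measured compounds shown here, compound 3 (`COC(=O)N1[C@@H]2C=C[C@@](OC)(C(=O)c3c2cc(OC)c(OC)c3OCc2ccc(Cl)cc2)N1C(=O)OC`) gives 55.9 ug/mL, the only true number so far. Compound 1 therefore sits at the limit of > 300 ug/mL in this assay, at which 2 of the 3 values shown sit. Compound 4 (`CCCCOc1c(OC)c(OC)cc2c1C(=O)[C@]1(OC)C=C[C@H]2N(C(=O)OCC)N1C(=O)OCC`) differs from it by ethyl in place of hydrogen on a saturated chain carbon, two bonds along the chain from an oxygen on an aromatic ring. For the measured compounds named here, no measured step covers this change. Going by the values given here, the one step available, an at least 5.3-fold lower number from compound 2 to compound 3 (0.72 log units; beyond the scatter), is a chloro in place of methoxy change and bears only indirectly, showing that a number can be reached. A modest move toward lower numbers in this assay is expected, with an estimated at least 1.5-fold lower number from compound 1 to compound 4 (0.17 log units; that floor lies within the scatter). A result at the limit again would be no surprise. For compound 4 the estimate is 200 ug/mL, with an expected range of 60 ug/mL to 500 ug/mL.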

Compound 4, concentration for half-maximal effect: 76 ug/mL
Estimate against measurement, compound 4: 2.6-fold (0.42 log units) above; low and high end bracket the measured number.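

Going from ethoxy to butoxy gives an at least 3.9-fold lower number from compound 1 to compound 4 (0.59 log units; beyond the scatter) in this assay. A change in chain length at this position alone is therefore enough to bring a value in this series off the limit. The full size of the step stays unknown, as the starting value is a limit and such limits remain frequent in this set: the limit of > 300 ug/mL in this assay, at which 2 of the 4 values shown sit.

Still open, on these data alone, is whether a longer chain, such as hexyloxy, continues in the same direction. Also open, as far as these compounds go, is whether an amine or a carboxylic acid at the end of the chain would preserve the change.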